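This account rests on a few compounds, and the source may have more. Where it says the series, first, only, none or still open, it means among the compounds named here.

Compound 1, `CCCCNC(=O)C1C(C(=O)O)[C@@H]2CC[C@H]1O2`: 10000 nM
Compound 2, `CCCNC(=O)C1C(C(=O)O)[C@@H]2CC[C@H]1O2`: 10000 nM
Compound 3, `C=CCNC(=O)C1C(C(=O)O)[C@@H]2CC[C@H]1O2`: 10000 nM

The three compounds share one core and differ only in the group carried on the amide nitrogen. In an ADME assay on SW480 cells (Homo sapiens) for cytotoxicity, read by MTT assay, with a stated time of 72 h (on this read-out lower numbers stand for stronger inhibition of growth and higher numbers for weaker inhibition of growth), compound 1 gives 10000 nM, compound 2 gives 10000 nM and compound 3 gives 10000 nM. The steps between them show no movement: no change at the digits printed from compound 1 to compound 2 (within the scatter), no change at the digits printed from compound 1 to compound 3 (within the scatter) and no change at the digits printed from compound 2 to compound 3 (within the scatter). Compound 3 therefore stands level with compounds 1 and 2; no one of the three can be called stronger or weaker than another.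

Compound 4, `O=C(O)CCCNC(=O)C1C(C(=O)O)[C@@H]2CC[C@H]1O2`, keeps the same core and changes the nitrogen substituent once more: 2-carboxyethyl in place of vinyl on a saturated chain carbon bound to an amide-type nitrogen. Within the data shown here, none of the measured steps covers an entering carboxylic acid, so the only guide is that three different chain groups at this position, from compound 1 through compound 3, gave the same reading in this assay. On that basis the expected step is no change at the digits printed from compound 3 to compound 4 (within the scatter), with no movement beyond the scatter. The estimate for compound 4 in this assay is 10000 nM, with a range from 5000 nM to 20000 nM.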

Compound 4, concentration for 50% growth inhibition: 10000 nM
Estimate against measurement, compound 4: no gap at the digits printed; the range from low to high includes it.
By their numbers in this assay, from the lowest: compounds 1, 2, 3 and 4 (each within the scatter of the next).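

In this assay the reading does not move when 2-carboxyethyl enters in place of vinyl on a saturated chain carbon bound to an amide-type nitrogen: the steps read no change at the digits printed from compound 3 to compound 4 (within the scatter) and no change at the digits printed from compound 2 to compound 4 (within the scatter) and no change at the digits printed from compound 1 to compound 4 (within the scatter) for this new chain. Until now this place had carried only plain carbon chains, and it now also carries a chain ending in a carboxylic acid, with one more hydrogen-bond donor and one more acceptor than vinyl, and the reading is the same. Nothing measured here offers an explanation for this flat result.

All four compounds share one reading, so none of them shows what kind of group at this place, if any, would shift growth inhibition in these cells. An amine at the end of the chain, a longer plain carbon chain, or a methyl ester in place of the carboxylic acid on the shared core could each be read against these four, and the compounds shown do not say how any of them would behave.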